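The source may report more compounds than this note shows. Statements on the series, on what has been measured and on what is new or still open speak of the compounds shown alone.

Compound 1 `COc1cc(-c2nnc(SCC(=O)c3ccc(C)cc3)n2N)cc(OC)c1OC` gives 31300 nM in a functional assay on PC-3 cells (Homo sapiens) for antiproliferative activity, read by MTT assay, with a stated time of 48 h; on this read-out lower numbers stand for stronger inhibition and higher numbers for weaker inhibition. Compound 2 `COc1cc(-c2nnc(SCC(=O)c3ccc(F)cc3)n2N)cc(OC)c1OC` reaches only a limit in this assay, > 100000 nM, so for compound 2 no number is known, just (the limit of > 100000 nM in this assay, at which 1 of the 2 values shown sits).

Compound 3 `COc1cc(-c2nnc(SCC(=O)c3cccc(Br)c3)n2N)cc(OC)c1OC` differs from compound 2 by 3-bromophenyl in place of 4-fluorophenyl on a carbonyl carbon. Going by the values given here, the one measured step touching this aryl group is an at least 3.1-fold higher number from compound 1 to compound 2 (0.50 log units; beyond the scatter), which went toward weaker inhibition. The new change alters both the halogen and its named place on the ring, so the direction is uncertain; some return toward the region of compound 1 is plausible but unsupported. The expected step is an at least 2.0-fold lower number from compound 2 to compound 3 (0.30 log units; that floor lies within the scatter). Compound 3 is expected to give 50000 nM, between 15000 nM and 150000 nM, with a real chance of another limit.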

Compound 3, half-maximal inhibitory concentration: > 100000 nM
Compound 3 ended at the assay's limit (the forecaster's own chance of this, stated with the estimate: 40%); middle value at least 2.0-fold (0.30 log units) away from the limit.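

The 3-bromophenyl group on the carbonyl carbon, like the 4-fluorophenyl group, gives no number in this assay, so the step between these two limits cannot be read. Set against the 4-methylphenyl group, the change gives an at least 3.1-fold higher number from compound 1 to compound 3 (0.50 log units; beyond the scatter), so a second halogen-bearing aryl group now falls on the weaker side of compound 1, and neither of the two goes against this. Only compound 1 gives a number so far: the limit of > 100000 nM in this assay, at which 2 of the 3 values shown sit.

Open, as far as these compounds go, is whether 3-methylphenyl would give a number like compound 1. Also open, from the compounds shown here alone, is whether an aryl group carrying an amine or a carboxylic acid would give a number at all.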